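Triazole substituent exchange on an amidoxime series

The source may hold more compounds than are shown below. What is called first, only, known or untested is meant among the compounds shown, and "the series" means these compounds.

Working notes on a set sharing one core. For the measured compounds named here, in an assay on tissue (HeLa cells) for inhibition of Indoleamine 2,3-dioxygenase 1 (Homo sapiens), read by spectrophotometry, with a stated time of 48 h (a higher number here means a weaker inhibitor, a lower number a stronger inhibitor), compound 3 `O/N=C(\Nc1ccc(F)c(Br)c1)c1nonc1NCCn1cc(-c2cccc(O)c2)nn1` gives 13.6 nM, the only number in hand. Going by the values given here, for compound 1 `COCc1cn(CCNc2nonc2/C(=N/O)Nc2ccc(F)c(Br)c2)nn1` the outcome stands as "not determined" (no result reported), and for compound 2 `O/N=C(\Nc1ccc(F)c(Br)c1)c1nonc1NCCn1cc(-c2ccccc2)nn1` it stands as "not determined" (no result reported), so no step between measured compounds can be drawn. Compound 4 `OCCOCc1cn(CCNc2nonc2/C(=N/O)Nc2ccc(F)c(Br)c2)nn1` differs from compound 3 in one place: (2-hydroxyethoxy)methyl in place of 3-hydroxyphenyl on an aromatic carbon. The move from a ring-bearing group to a short open chain is expected to cost some potency, and the step from compound 3 to compound 4 in this assay is estimated as a 2.6-fold higher number from compound 3 to compound 4 (0.41 log units; beyond the scatter), probably beyond the usual scatter. Compound 4 is therefore expected to give 35 nM in this assay, within 9 nM to 140 nM.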

Compound 4, half-maximal inhibitory concentration: 2.16 nM
Estimate against measurement, compound 4: 16-fold (1.21 log units) above, outside the stated range (below it).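

On an aromatic carbon of the five-membered aromatic ring with 3 nitrogen, a low number in this assay does not depend on a ring-bearing group: (2-hydroxyethoxy)methyl in place of 3-hydroxyphenyl gives a 6.3-fold lower number from compound 3 to compound 4 (0.80 log units; beyond the scatter). Compound 3 alone could not show that an open chain is accepted here, let alone with a gain. Nothing measured here bears on the reason for this gain.

Steps to compound 1 and compound 2 cannot be read, so the contribution of the chain's hydroxyl stays open. Also open, on these data alone, is how an amine or a carboxylic acid in place of that hydroxyl, or a longer chain, would read.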